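Thiophenyl for cyclopentenyl on the benzylic aryl ring

A few compounds are considered here, and "the series" means these few. Any claim that something is new, unique, unknown or untested is made for them only; others in the source may bear on it.

Three compounds of the series have numbers in an assay on isolated protein for inhibition of ubiquitin carboxyl-terminal hydrolase 7 (Homo sapiens), with stated times of 30 min and 2 h; a lower number here means a stronger inhibitor, a higher number a weaker inhibitor. Compound 1 `Cn1nc2c(=O)n(CC3(O)CCN(Cc4ccc(-n5ccnc5)cc4Cl)CC3)cnc2c1-c1ccc(CN)cc1` gives 228 nM. Compound 2 `Cn1cc(-c2ccc(CN3CCC(O)(Cn4cnc5c(-c6ccc(CN)cc6)n(C)nc5c4=O)CC3)c(Cl)c2)cn1` gives 291 nM. Compound 3 `Cn1nc2c(=O)n(CC3(O)CCN(Cc4ccc(C5=CCCC5)cc4Cl)CC3)cnc2c1-c1ccc(CN)cc1` gives 76.9 nM, the lowest number of the three, with both steps to it beyond the scatter: a 3.0-fold lower number from compound 1 to compound 3 (0.47 log units; beyond the scatter) and a 3.8-fold lower number from compound 2 to compound 3 (0.58 log units; beyond the scatter). The step between the two heteroaryl compounds is small: a 1.3-fold higher number from compound 1 to compound 2 (0.11 log units; within the scatter).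

Compound 4 `Cn1nc2c(=O)n(CC3(O)CCN(Cc4ccc(-c5ccsc5)cc4Cl)CC3)cnc2c1-c1ccc(CN)cc1` is not yet measured. The change from compound 3 is thiophen-3-yl in place of cyclopent-1-en-1-yl on an aromatic carbon. The two steps that bear on it are those into compound 3 from compound 1 and compound 2, where a five-membered aromatic heterocycle gave way to cyclopent-1-en-1-yl and the number fell by a modest amount each time. Compound 4 returns to a five-membered aromatic ring, so a modest rise in this assay is expected, smaller than those steps since thiophen-3-yl carries a single hetero atom and no more than one acceptor. The expected step is a 1.7-fold higher number from compound 3 to compound 4 (0.23 log units; within the scatter). Compound 4 is estimated at 130 nM, within 60 nM to 300 nM.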

Compound 4, half-maximal inhibitory concentration: 59.5 nM
Estimate against measurement, compound 4: 2.2-fold (0.34 log units) above, outside the stated range (below it).
By their numbers in this assay, from the lowest: compounds 4 and 3 (each within the scatter of the next); then compounds 1 and 2 (each within the scatter of the next).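

In this assay, replacing cyclopent-1-en-1-yl with thiophen-3-yl on this aromatic carbon gives a 1.3-fold lower number from compound 3 to compound 4 (0.11 log units; within the scatter) and leaves the two groups unresolved, so an aromatic five-membered ring is compatible here with a number as low as that of the non-aromatic ring. The nitrogen-containing rings of compound 1 and compound 2 remain separate from thiophen-3-yl, with a 3.8-fold lower number from compound 1 to compound 4 (0.58 log units; beyond the scatter) and a 4.9-fold lower number from compound 2 to compound 4 (0.69 log units; beyond the scatter), so among these four compounds, the higher numbers go with those two rings and not with aromatic character alone. No measurement available here accounts for these steps.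

From the compounds shown here alone, the place of furan-3-yl, thiophen-2-yl or a saturated cyclopentyl group at this position remains open. Going by these compounds, it is also open whether the same ordering would hold with a methyl or methoxy group in place of the chloro group.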